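Shortening the linker toward a methyl-bearing carboxyphenyl group

This account rests on a few compounds, and the source may have more. Where it says the series, first, only, none or still open, it means among the compounds named here.

Of the compounds shown here, three sharing one core have been measured in an assay on HEK293 cells for positive allosteric modulation of metabotropic glutamate receptor 3 (Rattus norvegicus), read by thallium flux, with a stated time of 2.5 min; a lower number here means a smaller maximal response, a higher number a larger maximal response. Compound 1 `Cc1c(OCCCCOCOc2ccc(C(=O)O)cc2)ccc(C(=O)CC2CCCC2)c1O` gives 46.9% in this assay, the second highest of the three numbers. Compound 2 `Cc1c(OCCCCOc2cccc(C(=O)O)c2)ccc(C(=O)CC(C)C)c1O` reaches 69.9% in this assay, a number higher than that of compound 1 by more than the usual scatter. Compound 3 `CC(=O)c1ccc(OCCCCOc2ccc(C(=O)O)cc2C)c(C)c1O` shows 25.4% in this assay, a number lower than that of compound 1, again beyond the scatter. Going by the values given here, no two of these measured compounds differ in only one place, so no single step can be drawn between them.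

Compound 4 `Cc1ccc(C(=O)O)cc1OCCCCOc1ccc(C(=O)CC2CCCC2)c(O)c1C` has not been measured in this assay. It differs from compound 1 as follows: 5-carboxy-2-methylphenyl in place of (4-carboxyphenoxy)methyl on an oxygen on a saturated carbon. The chain between the two aromatic ends thus becomes shorter, and a methyl group appears on the carboxy-bearing ring.

Among the compounds with values here, since no single-change step exists among the measured compounds, the size of the step in this assay can only be guessed. A moderate step is expected, its direction uncertain, because the values of compound 2 at 69.9% and compound 3 at 25.4% lie on either side of compound 1. Compound 4 is therefore estimated at 52% in this assay, within the range 28% to 76%, a step of a number 5.1 percentage points higher from compound 1 to compound 4 (within the scatter) expected from compound 1.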

Compound 4, largest response reached (reported as percent of maximum), in percent of the reference or control that the assay uses: 26.9%
Beside the measured number, compound 4's estimate is 25.1 percentage points above it, outside the stated range (below it).
By their numbers in this assay, from the lowest: compounds 3 and 4 (each within the scatter of the next); then compound 1; then compound 2.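

In this assay, going by these compounds alone, replacing (4-carboxyphenoxy)methyl with 5-carboxy-2-methylphenyl on an oxygen on a saturated carbon gives the first step in this set that can be read for a single place: a number 20 percentage points lower from compound 1 to compound 4 (beyond the scatter). The maximal response therefore depends on what is attached at this oxygen, even though both groups carry a carboxy-bearing aromatic ring of carbon only and differ by just one heavy atom and one hydrogen-bond acceptor. Nothing measured here accounts for the fall in response.

This one exchange alters the chain, adds a methyl group and changes where the carboxy group stands on the ring, so the step cannot be divided among these features, and it remains open which of them matters. As far as these compounds go, it also remains open whether a methoxy group in place of that methyl group, a tetrazole in place of the carboxylic acid, or a longer chain at this oxygen would restore the response seen with compound 1 or take it further.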